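Working notes: exchanging the group on the aromatic nitrogen

This account rests on a few compounds, and the source may have more. Where it says the series, first, only, none or still open, it means among the compounds named here.

Measured in a toxicity assay on HEK-293T cells (Homo sapiens) for cytotoxicity, read by MTT assay, with a stated time of 72 h; a higher number here means a weaker inhibitor, a lower number a stronger inhibitor:
- compound 1 `O=C1c2c[n+]([O-])c3ccccc3c2C(=O)c2c1c1ccccc1n2Cc1cn([C@@H]2C[C@H](O)[C@@H](CO)O2)nn1`: 820 nM
- compound 2 `O=C1c2c[n+]([O-])c3ccccc3c2C(=O)c2c1c1ccccc1n2Cc1cn(CC(O)CO)nn1`: 760 nM

Only these two values exist so far, and compound 2, at 760 nM, cannot be separated from compound 1 in this assay. Compound 3 `O=C1c2c[n+]([O-])c3ccccc3c2C(=O)c2c1c1ccccc1n2Cc1cn([C@H]2C[C@H](O)[C@@H](CO)O2)nn1` is still to be measured. Relative to compound 2, it carries 4-hydroxy-5-(hydroxymethyl)oxolan-2-yl in place of 2,3-dihydroxypropyl on an aromatic nitrogen. Within the data shown here, one measured step bears on this change: a 1.1-fold lower number from compound 1 to compound 2 (0.03 log units; within the scatter). It exchanges the same named groups in the opposite direction and stays within the scatter. Compound 1 and compound 3 differ in stereochemistry, and no measurement covers that difference. No change beyond the scatter is therefore expected, and the estimated move is a 1.1-fold higher number from compound 2 to compound 3 (0.02 log units; within the scatter). Compound 3 is expected at 800 nM, with an estimated range of 400 nM to 1600 nM.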

Compound 3, half-maximal inhibitory concentration: 3600 nM
Beside the measured number, compound 3's estimate is 4.5-fold (0.65 log units) below it; the whole stated range lies below it.
By their numbers in this assay, from the lowest: compounds 2 and 1 (each within the scatter of the next); then compound 3.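

In this assay, the exchange of the two named groups on the aromatic nitrogen is no longer neutral: it gives a 4.7-fold higher number from compound 2 to compound 3 (0.68 log units; beyond the scatter), whereas the same pair of groups gave a 1.1-fold lower number from compound 1 to compound 2 (0.03 log units; within the scatter). The stereochemical comparison gives a 4.4-fold higher number from compound 1 to compound 3 (0.64 log units; beyond the scatter), with a stereocentre at a saturated ring carbon drawn S in compound 1 and R in compound 3. At this position, the outcome therefore depends on the configuration of the ring and not on the presence of the ring alone, and the shift can be assigned to that stereocentre: the fact that compounds 1 and 3 differ only in the configuration as drawn.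

The compounds shown leave open what the other two stereocentres of the ring contribute. Also open, from the compounds shown here alone, is how an amine or a carboxylic acid in place of the ring hydroxyl groups, or a longer chain in place of 2,3-dihydroxypropyl, would read here.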